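The source may report more compounds than this note shows. Statements on the series, on what has been measured and on what is new or still open speak of the compounds shown alone.

Measured compounds in this series:

Compound 1 `C=CCONC(=O)CN1C(=O)CSC1=O` in an ADME assay on RAW264.7 cells (Mus musculus) for cytotoxicity, read by neutral red uptake, with a stated time of 24 h (on this read-out lower numbers stand for higher toxicity in this test and higher numbers for lower toxicity in this test), gives > 128000 nM, which is a limit of the assay and not a number.
Compound 2 `C=CCONC(=O)C(C)N1C(=O)CSC1=O` in this assay gives > 128000 nM, again a limit of the assay.
Compound 3 `O=C(CN1C(=O)S/C(=C\c2ccccc2)C1=O)NOCc1ccccc1` in this assay gives > 128000 nM, also a limit of the assay.

Compound 1 and compound 2 differ in one place: methyl in place of hydrogen on a saturated chain carbon bound to an amide-type nitrogen in a ring and a carbonyl carbon. The step in this assay is a step that the two limits leave unreadable from compound 1 to compound 2, so both values sit at the same limit and the size of this change cannot be read from the pair. The only common ground across the measured set is the limit of > 128000 nM in this assay, at which 3 of the 3 values shown sit.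

Compound 4 `CC(C(=O)NOCc1ccccc1)N1C(=O)S/C(=C\c2ccccc2)C1=O` is not yet measured. It differs from compound 3 by methyl in place of hydrogen on a saturated chain carbon bound to an amide-type nitrogen in a ring and a carbonyl carbon; the place given for this change is word for word the same as for the change from compound 1 to compound 2, so it is the same change made on a second core. How the core of compound 3 differs from the core of compound 1 is not broken down here.

For compound 4 in this assay the expected step from compound 3 is a step that the limit leaves unreadable from compound 3 to compound 4, which rests on compound 1 at > 128000 nM and compound 2 at > 128000 nM both sitting at the limit, with the change itself leaving no readable size. Compound 4 is therefore expected at about 200000 nM, most likely reported as a limit once more, with the estimate spanning 100000 nM to 600000 nM.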

Compound 4, half-maximal cytotoxic concentration: > 128000 nM
Compound 4 was reported as a limit (the forecaster's own chance of this, stated with the estimate: 85%); the middle value lies beyond the limit too.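

Compound 3 and compound 4 both sit at a limit of the assay in this assay, so no new step can be read from this pair, and the change to methyl again leaves no readable size. Left open is whether any compound shown has a readable half-maximal cytotoxic concentration and whether this change has any size on either core, the only common ground being: the limit of > 128000 nM in this assay, at which 4 of the 4 values shown sit.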